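The source may hold more compounds than are shown below. What is called first, only, known or untested is meant among the compounds shown, and "the series" means these compounds.

Working notes on the series. Compound 1 `O=C(Nc1cc2cc[nH]c(=O)c2cc1Cl)[C@@H]1CCCN1` carries pyrrolidin-2-yl on the carbonyl carbon of the amide attached to the shared core. In a functional assay (aorta) with Rattus norvegicus as the target (a higher number here means that more compound is needed for the effect, a lower number that less compound is needed), compound 1 is recorded as "not determined" (no result reported), so it stands without a number. Compound 3 `CC(C)[C@@H](N)C(=O)Nc1cc2cc[nH]c(=O)c2cc1Cl` is likewise recorded as "not determined" (no result reported) in this assay and stands without a number. Within the data shown here, the only number in the set comes from compound 2 `N[C@H]1CC[C@@H](C(=O)Nc2cc3cc[nH]c(=O)c3cc2Cl)CC1`, which in this assay gives 180 nM. Compound 4 `NCC(=O)Nc1cc2cc[nH]c(=O)c2cc1Cl` has not yet been measured in this assay.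

The change from compound 1 to compound 4 is aminomethyl in place of pyrrolidin-2-yl on a carbonyl carbon. Among the measured compounds shown here, no pair of measured compounds differing in one place exists, so no step size can be drawn from the data. With compound 1 lacking a number, the step is expected to be of modest size in this assay, in either direction, and not clearly beyond the scatter of the measurement. Compound 2 with 180 nM in this assay is the only anchor for the aminoalkyl amides of this core. On that basis compound 4 is expected to give about 400 nM in this assay, within a range of 60 nM to 3000 nM, and the measurement will show whether this holds.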

Compound 4, half-maximal effective concentration: 2500 nM
Compound 4: the middle estimate sits 6.3-fold (0.80 log units) below what was measured, and the stated range covers the measured number.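

In this assay, among these compounds, aminomethyl in place of 4-aminocyclohexyl on a carbonyl carbon gives a 14-fold higher number from compound 2 to compound 4 (1.14 log units; beyond the scatter), which is the first step that can be read. It shows that the group at this position of the amide is not interchangeable among the aminoalkyl amides of the shared core: of the two with numbers, compound 2 needs clearly less compound for the effect than compound 4. The steps involving compound 1 and compound 3 cannot be read, as neither compound has a number, and no supporting data are available to explain the size of the step seen here.

A single step does not separate the contribution of the ring from that of the longer distance to the amine, and a longer open chain such as 4-aminobutyl on the same carbonyl carbon would bear on this. Going by these compounds, it also remains open how far the amine itself matters, which a cyclohexyl group without the amine, or a carboxylic acid in place of the amine, would address.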